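Amine exchange on the methylated analogue compound 3

This account rests on a few compounds, and the source may have more. Where it says the series, first, only, none or still open, it means among the compounds named here.

Measured so far:
Compound 1 `CC(C)(C)c1cc2[nH]nc(N)c2c(=O)[nH]1` gives 65% in an assay on isolated protein for inhibition of ribosomal protein S6 kinase alpha-5 (Homo sapiens), read by mobility shift assay, tested at 30 uM; on this read-out lower numbers stand for less inhibition and higher numbers for more inhibition at the one concentration tested (going by the name of the read-out).
Compound 2 `Cc1cc2[nH]nc(N)c2c(N2CCCCC2)n1` gives 87% in this assay.
Compound 3 `Cc1cc2c(c(N)nn2C)c(N2CCCCC2)n1` gives 7% in this assay.

Compound 3 stands lowest of the three numbers in this assay; compound 1 sits above it beyond the scatter, and compound 2 sits further above it, also beyond the scatter. Within the data shown here, the one step between neighbours that differ in a single place, a number 80 percentage points lower from compound 2 to compound 3 (beyond the scatter), is large, and it arises from methyl in place of hydrogen on an aromatic nitrogen.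

Compound 4 `COCCNc1nc(C)cc2c1c(N)nn2C` keeps the methyl on the aromatic nitrogen of compound 3 and differs from it in one place: (2-methoxyethyl)amino in place of piperidin-1-yl on an aromatic carbon. Among the measured compounds shown here, no measured pair shows this exchange, so the step from compound 2 to compound 3 is the only one that bears on the question, and only indirectly: it shows that compound 3, carrying the methyl, gives a low number in this assay, and compound 4 retains that methyl. The exchange of the amine is therefore expected to move the number little, if at all, beyond the scatter, with the direction open; the step of a number 3 percentage points higher from compound 3 to compound 4 (within the scatter) is the expected change. Compound 4 is estimated at 10% in this assay, within 0% to 30%.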

Compound 4, a percentage reported as inhibition, at one concentration (the size of the read-out at that concentration, not a potency): 0%
For compound 4 the middle estimate is 10 percentage points above the measured one, and the stated range covers the measured number.
By their numbers in this assay, from the lowest: compounds 4 and 3 (each within the scatter of the next); then compound 1; then compound 2.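

In this assay, exchanging piperidin-1-yl for (2-methoxyethyl)amino on the aromatic carbon next to the ring nitrogen gives a number 7 percentage points lower from compound 3 to compound 4 (within the scatter), so with the methyl on the aromatic nitrogen kept, this pair shows no readable difference between a six-membered non-aromatic ring and an open chain at this position. The open chain also brings a hydrogen-bond donor that piperidin-1-yl lacks, and that change in the count leaves no readable mark on the number here. Neither amine lifts the number out of the low range, where compound 3 gives 7% and any smaller difference between the two amines could stay hidden. No measurement at hand offers a reason for this result.

Still open, on these data alone, is whether the same exchange gives a readable step with hydrogen on the aromatic nitrogen, the form in which compound 2, carrying piperidin-1-yl, gives 87% in this read-out. Also open, as far as these compounds go, is how morpholine, a primary amine or a longer chain such as (3-methoxypropyl)amino would read at this position, and how an ethyl group would read on the aromatic nitrogen in place of the methyl.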